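A few compounds are considered here, and "the series" means these few. Any claim that something is new, unique, unknown or untested is made for them only; others in the source may bear on it.

Series notes. Going by the values given here, compound 1 `N#Cc1ccc(Nc2nccc(Nc3ccc(-c4ccc(C#N)cc4)cc3F)n2)cc1` is tested in a functional assay on MT4 cells (Homo sapiens) for cytotoxicity, read by MTT assay, with a stated time of 5 days (on this read-out lower numbers stand for higher toxicity in this test and higher numbers for lower toxicity in this test), and gives 308000 nM, the only numeric value among the two measured compounds. Compound 2 `N#Cc1ccc(Nc2nccc(Nc3ccc(-c4ccc(C#N)cc4)c(F)c3)n2)cc1` returns only a limit of the assay, > 271000 nM, with no number behind it; this is the situation summarised by the limit of > 271000 nM in this assay, at which 1 of the 2 values shown sits. Compound 3 `Cc1cc(-c2ccc(C#N)cc2)ccc1Nc1ccnc(Nc2ccc(C#N)cc2)n1` differs from compound 1 by methyl in place of fluoro on an aromatic carbon, a methyl in place of fluoro on an aromatic carbon. Among the compounds with values here, no measured step of this kind exists in the set, so for compound 3 the step of a 1.0-fold lower number from compound 1 to compound 3 (0.01 log units; within the scatter) is expected to stay within the usual scatter, in no particular direction. Compound 3 is therefore estimated at 300000 nM, between 150000 nM and 600000 nM.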

Compound 3, half-maximal cytotoxic concentration: 9200 nM
Compound 3: the middle estimate sits 33-fold (1.51 log units) above what was measured, outside the stated range (below it).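

In this assay, this position is not indifferent to the exchange of one heavy atom for another: methyl in place of fluoro, ortho to a large group and meta to a 4-cyanophenyl group, gives a 33-fold lower number from compound 1 to compound 3 (1.52 log units; beyond the scatter) as a large step. Compound 3 is thus the more toxic of this pair in this test. Compound 2 gives only a limit, so no step to it can be read: the limit of > 271000 nM in this assay, at which 1 of the 3 values shown sits.

Whether the step follows from gaining methyl or from losing fluoro stays open, with hydrogen, chloro and methoxy at this position absent from the compounds shown. Also open, on these data alone, is whether a longer chain such as ethyl would move the value further.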